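A few compounds are considered here, and "the series" means these few. Any claim that something is new, unique, unknown or untested is made for them only; others in the source may bear on it.

In a physicochemical assay for solubility (a lower number here means a less soluble compound, a higher number a more soluble compound), compound 1 `CS(=O)(=O)c1ccc(-n2nc(C(F)(F)F)cc2-c2ccccc2)nc1` gives 50 ug/mL and compound 2 `CS(=O)(=O)c1ccc(-n2nc(C(F)(F)F)c(C#N)c2-c2ccccc2)nc1` gives 100 ug/mL, so the two stand within the scatter of each other. Compound 3 `C[C@@H]1CN(c2cc(C(F)(F)F)nn2-c2ccc(S(C)(=O)=O)cn2)[C@H](C)CO1` is not yet measured and differs from compound 1 as follows: a group of 8 heavy atoms (6 carbon, 1 nitrogen, 1 oxygen; one six-membered non-aromatic ring with 2 hetero atoms) in place of a group of 6 heavy atoms (6 carbon; one six-membered aromatic ring of carbon only), on an aromatic carbon. Among the measured compounds shown here, the only measured step, a 2.0-fold higher number from compound 1 to compound 2 (0.30 log units; within the scatter), is a different change, cyano in place of hydrogen on an aromatic carbon, and offers only weak guidance here. No step beyond the scatter is expected in this assay, and the estimated step is a 1.4-fold higher number from compound 1 to compound 3 (0.15 log units; within the scatter). For compound 3 the expected value is 70 ug/mL, with an estimated range from 20 ug/mL to 200 ug/mL.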

Compound 3, solubility: 100 ug/mL
Compound 3: the middle estimate sits 1.4-fold (0.15 log units) below what was measured, and the stated range covers the measured number.
By their numbers in this assay, from the lowest: compounds 1, 2 and 3 (each within the scatter of the next).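

In this assay, the aromatic carbon that carries phenyl also takes a six-membered non-aromatic ring with 2 hetero atoms, with a 2.0-fold higher number from compound 1 to compound 3 (0.30 log units; within the scatter). Among the compounds shown here, this is the first view of this position, and even this exchange of an aromatic carbon ring for a non-aromatic ring with 2 hydrogen-bond acceptors stays inside the scatter. No measurement at hand speaks to the reason for this result. The compounds shown leave open how an open-chain amine or a piperidine would read at this carbon. They also leave open how the other arrangements of the 2 defined stereocentres would read, and how this ring would read alongside the cyano group of compound 2.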